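From tert-butyl to cyclopentenyl: an expected step

The compounds below may be only part of what the source reports. "The series", "measured", "known", "first", "only" and "open" are said of these compounds alone.

Of the compounds shown here, two have been measured so far in an assay on isolated protein for inhibition of tyrosine-protein kinase receptor UFO (Homo sapiens), read by FRET and Z'-LYTE, with a stated time of 1.5 h; on this read-out lower numbers stand for stronger inhibition and higher numbers for weaker inhibition. Compound 1 `CCc1ccc2c(c1)c(=O)c(C(=O)Nc1ccc(Oc3ncnc4[nH]cc(-c5ccccc5)c34)c(F)c1)c(C)n2C` gives 6 nM, and compound 2 `Cc1c(C(=O)Nc2ccc(Oc3ncnc4[nH]cc(-c5ccccc5)c34)c(F)c2)c(=O)c2cc(C(C)(C)C)ccc2n1C` gives 42 nM. Among the compounds with values here, the single step between them, a 7.0-fold higher number from compound 1 to compound 2 (0.85 log units; beyond the scatter), lies beyond the scatter. Compound 2 therefore stands with the higher of the two numbers, its nearest neighbour being compound 1 at the other end of that step.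

Compound 3 `Cc1c(C(=O)Nc2ccc(Oc3ncnc4[nH]cc(-c5ccccc5)c34)c(F)c2)c(=O)c2cc(C3=CCCC3)ccc2n1C` has not yet been measured. It differs from compound 2 in one place: cyclopent-1-en-1-yl in place of tert-butyl on an aromatic carbon. Within the data shown here, no measured step covers this exact exchange; the only step known, a 7.0-fold higher number from compound 1 to compound 2 (0.85 log units; beyond the scatter), concerns the same position and shows that the group there shifts the number by a modest amount. Replacing tert-butyl with another group at that position is therefore expected to shift the number again, most plausibly back toward the lower end, though by less than that earlier step. For compound 3 the expected step is a 2.8-fold lower number from compound 2 to compound 3 (0.45 log units; beyond the scatter). Compound 3 is thus estimated at 15 nM in this assay, within a range from 5 nM to 50 nM.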

Compound 3, half-maximal inhibitory concentration: 3320 nM
Compound 3: the middle estimate sits 220-fold (2.35 log units) below what was measured; measured number outside the range, above it.
By their numbers in this assay, from the lowest: compound 1; then compound 2; then compound 3.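

In this assay, putting cyclopent-1-en-1-yl in place of tert-butyl gives a 79-fold higher number from compound 2 to compound 3 (1.90 log units; beyond the scatter) and so is a far larger step than the earlier one at this position, and measured against the ethyl group the same ring gives a 550-fold higher number from compound 1 to compound 3 (2.74 log units; beyond the scatter) on the same aromatic carbon. The earlier pair had shown only a modest change here, a 7.0-fold higher number from compound 1 to compound 2 (0.85 log units; beyond the scatter), so the position now appears far less forgiving than that step alone suggested, and the large step comes with an exchange that adds a five-membered ring and a double bond outside aromatic rings, while neither group carries a hydrogen-bond donor or acceptor. No supporting information bears on why the number rises so steeply.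

The compounds shown leave open whether the rise goes with the ring itself or with its double bond, a question that a saturated cyclopentyl group at this place would help to settle. They also leave open how a group containing nitrogen or oxygen, such as an amine or a methoxy group, would read at this position, as the three groups compared here hold only carbon and hydrogen.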